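Ring-nitrogen substituent removal in a Substance-P receptor series

A few compounds are considered here, and "the series" means these few. Any claim that something is new, unique, unknown or untested is made for them only; others in the source may bear on it.

Three members of the series carry measurements in an assay on CHO cells for displacement of a labelled ligand from Substance-P receptor (Homo sapiens); a higher number here means a weaker inhibitor, a lower number a stronger inhibitor. Compound 1 `O=C1NC[C@@](COCc2cc(C(F)(F)F)cc(C(F)(F)F)c2)(c2ccccc2)N1` gives 6 nM. Compound 2 `O=C1NC(COCc2cc(C(F)(F)F)cc(C(F)(F)F)c2)(c2ccc(F)cc2)CN1C1CCOCC1` gives 6.3 nM. Compound 3 `C[C@@H](OC[C@@]1(c2ccc(F)cc2)CN(CC(N)=O)C(=O)N1)c1cc(C(F)(F)F)cc(C(F)(F)F)c1` gives 0.4 nM. Compound 2 holds the highest of the three numbers; its gap to compound 1 lies within the scatter, so the two cannot be ordered, whereas compound 3 sits lower by a margin well beyond the scatter.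

The next member, compound 4 `O=C1NCC(COCc2cc(C(F)(F)F)cc(C(F)(F)F)c2)(c2ccc(F)cc2)N1`, is not yet measured in this assay. Relative to compound 2 the change is hydrogen in place of oxan-4-yl on an amide-type nitrogen in a ring; the rest of the structure is unchanged.

Compound 1 also carries hydrogen on that ring nitrogen and its value 6 nM lies level with compound 2, so the substituent on this nitrogen appears to make little difference between those two. On that basis the step from compound 2 to compound 4 is expected to stay within the scatter, without a clear direction: a 1.1-fold lower number from compound 2 to compound 4 (0.02 log units; within the scatter). Compound 4 is therefore estimated at 6 nM in this assay, with a range from 2 nM to 18 nM.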

Compound 4, inhibition constant: 4.5 nM
The estimate for compound 4 lay 1.3-fold (0.12 log units) above the measured number; the range from low to high includes it.
By their numbers in this assay, from the lowest: compound 3; then compounds 4, 1 and 2 (each within the scatter of the next).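

In this assay, hydrogen in place of oxan-4-yl on the amide-type nitrogen in a ring gives a 1.4-fold lower number from compound 2 to compound 4 (0.15 log units; within the scatter) and so the two compounds cannot be ordered. Going by these compounds alone, this is the first direct reading at this position: with the 4-fluorophenyl group and the rest of the structure held fixed, a substituent of 6 heavy atoms containing a six-membered non-aromatic ring and a bare hydrogen read alike, whereas the earlier comparison with compound 1 also involved a change at the phenyl group. No measurement is available that bears on why the two read alike.

Compound 3 at 0.4 nM differs from compound 4 in more than one place, so the contribution of its ring-nitrogen substituent to that value stays unresolved. Also open, on these data alone, is whether a chain ending in an amine or a carboxylic acid on this nitrogen would read level with hydrogen and oxan-4-yl, or whether the tolerance seen for this one pair is limited to these two groups.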